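This account rests on a few compounds, and the source may have more. Where it says the series, first, only, none or still open, it means among the compounds named here.

Compound 1 `COC(=O)C1=C(C)NC(=S)NC1c1ccoc1`: 48%
Compound 2 `CCCOC(=O)C1=C(C)NC(=S)NC1c1ccoc1`: 45%
Compound 3 `CC1=C(C(=O)OCc2ccccc2)C(c2ccoc2)NC(=S)N1`: 36%

Three compounds share one core and differ only in the group on the ester oxygen. In an assay on membranes from HEK293 cells for displacement of a labelled ligand from adenosine receptor A2b (Homo sapiens), read by scintillation counting, with a stated time of 30 min, tested at 1 uM (a higher number here means more inhibition at the concentration tested (going by the name of the read-out), a lower number less inhibition), compound 1 gives 48%, the largest of the three numbers. The step of a number 3 percentage points lower from compound 1 to compound 2 (within the scatter) is within the scatter, so compound 1 and compound 2 cannot be told apart. The step of a number 12 percentage points lower from compound 1 to compound 3 (beyond the scatter) is beyond the scatter, a modest loss, while a number 9 percentage points lower from compound 2 to compound 3 (within the scatter) is again within it.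

Compound 4 `COC(=O)C1=C(C)NC(=S)NC1c1ccsc1` is the unmeasured compound. Among the measured compounds shown here, its single change from compound 1 is thiophen-3-yl in place of furan-3-yl on a saturated ring carbon. For the measured compounds named here, none of the measured steps touches this ring: all three vary the ester chain, and the ring on the saturated ring carbon is the same in every measured compound. Going by the values given here, there is thus no measured step that bears directly on this change. In the absence of such a step, the expectation is a step of about no size beyond the scatter in this assay. The estimated step is a number 2 percentage points lower from compound 1 to compound 4 (within the scatter). Compound 4 is therefore expected to give 46%, within a range from 30% to 62%.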

Compound 4, a percentage reported as inhibition, at one concentration (the size of the read-out at that concentration, not a potency): 38%
For compound 4 the middle estimate is 8 percentage points above the measured one; measured number inside the range.
By their numbers in this assay, from the lowest: compounds 3, 4, 2 and 1 (each within the scatter of the next, the first and the last beyond it).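

Among the compounds shown here, this is the first measured change at the ring on the saturated ring carbon, since the earlier steps all varied the ester chain. In this assay, putting thiophen-3-yl in place of furan-3-yl gives a number 10 percentage points lower from compound 1 to compound 4 (within the scatter) and so compound 1 and compound 4 cannot be told apart: at this position, sulfur can stand in place of oxygen in the five-membered aromatic ring with no difference that this assay can resolve. Nothing here offers an explanation for the size of this step.

The compounds shown leave open how a pyridyl or cyclohexyl group would behave on this same carbon. They also leave open whether thiophen-3-yl would give similar numbers when combined with the ester chains of compound 2 and compound 3.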